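Working notes: the step from compound 2 to compound 3

The source may report more compounds than this note shows. Statements on the series, on what has been measured and on what is new or still open speak of the compounds shown alone.

Measured so far in a functional assay on the whole organism (strain Swiss albino) for inhibition, with Mus musculus as the target, in the writhing test, with a stated time of 30 min, at a dose of 20 mg/kg by the oral route; a higher number here means a stronger effect of the compound at the dose given, a lower number a weaker effect:
compound 1, `Cc1c(/C=N\O)cc(-c2ccc(S(C)(=O)=O)cc2)n1-c1ccc(F)cc1`: 41%
compound 2, `Cc1c(/C=N\O)cc(-c2ccc(S(C)(=O)=O)cc2)n1-c1ccccc1`: 53%

Compound 2 stands highest of the two numbers; its nearest neighbour is compound 1, and the step of a number 12 percentage points higher from compound 1 to compound 2 (beyond the scatter) lies beyond the scatter but is modest. Among the compounds with values here, that step, hydrogen in place of fluoro on an aromatic carbon, is the only measured step.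

Compound 3, `Cc1c(C#N)cc(-c2ccc(S(C)(=O)=O)cc2)n1-c1ccccc1`, is not yet measured. It differs from compound 2 by a group of 2 heavy atoms (1 carbon, 1 nitrogen; no ring) in place of a group of 3 heavy atoms (1 carbon, 1 nitrogen, 1 oxygen; no ring), on an aromatic carbon. Within the data shown here, the one measured step concerns a different group at a different place and so does not bear on this change; the series holds no step for a cyano entering in place of a group of this kind. With nothing to lean on, no step beyond the scatter is expected in this assay, so the expected step is a number 5 percentage points lower from compound 2 to compound 3 (within the scatter), with a wide range. Compound 3 is estimated at 48% in this assay, between 28% and 66%.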

Compound 3, a percentage reported as inhibition, in the whole organism at one dose (the size of the read-out at that dose, not a potency): 42%
Compound 3: middle estimate off by 6 percentage points, on the high side, and the stated range covers the measured number.
By their numbers in this assay, from the lowest: compounds 1 and 3 (each within the scatter of the next); then compound 2.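

In this assay the aromatic carbon next to the ring atom that bears a methyl group is sensitive to the group it carries: cyano in place of the group of 3 heavy atoms gives a number 11 percentage points lower from compound 2 to compound 3 (beyond the scatter) at the one dose used. The group that leaves has 1 hydrogen-bond donor and 2 hydrogen-bond acceptors, against 0 and 1 for cyano, but a single step cannot separate these counts from the difference in heavy atoms or bond type. No measurement shown here explains this step.

From the compounds shown here alone, it remains open how a carboxylic acid, a carboxamide or an aminomethyl group at this position would read in this assay and whether the step would keep its size in the fluoro analogue, compound 1. With one dose, the compounds also leave open whether the step would persist at other doses.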